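Methoxy for methyl on the pyrazole aryl of compound 2

The compounds below may be only part of what the source reports. "The series", "measured", "known", "first", "only" and "open" are said of these compounds alone.

Working notes on the series. Among the compounds with values here, compound 2 `Cc1ccc(-c2nn(-c3ccc(Cl)cc3)cc2-c2cc(-c3ccc(Cl)cc3)[nH]c2-c2ccc(F)cc2)cc1` gives 38.3% in a functional assay on the whole organism (strain Wistar albino) for inhibition, with Rattus norvegicus as the target, read by paw edema, with stated times of 1 h and 2 h, at a dose of 0.32 mmol/kg by the intraperitoneal route (a lower number here means less inhibition, a higher number more inhibition at the dose given (going by the name of the read-out)), the second highest of the three numbers measured so far. Compound 1 `COc1ccc(-c2nn(-c3ccc(Cl)cc3)cc2/C=N\c2ccc(Cl)cc2)cc1` gives 69.6%, and compound 3 `COc1ccc(-c2[nH]c(-c3ccc(Cl)cc3)cc2-c2cn(-c3ccc(Cl)cc3)nc2-c2ccc(C)cc2)cc1` gives 9.38%. Within the data shown here, the only single-point step measured, a number 28.9 percentage points lower from compound 2 to compound 3 (beyond the scatter), lies beyond the scatter. Compound 4 `COc1ccc(-c2nn(-c3ccc(Cl)cc3)cc2-c2cc(-c3ccc(Cl)cc3)[nH]c2-c2ccc(F)cc2)cc1` differs from compound 2 by methoxy in place of methyl on an aromatic carbon. Among the measured compounds shown here, no measured pair carries exactly this change; the step from compound 2 to compound 3 concerns another phenyl ring and another departing group, so it bears on it only loosely. A modest decrease is expected for compound 4, estimated as a number 8.3 percentage points lower from compound 2 to compound 4 (within the scatter), though the direction is not secure. Compound 4 is therefore estimated at 30%, within a range from 10% to 55%.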

Compound 4, a percentage reported as inhibition, in the whole organism at one dose (the size of the read-out at that dose, not a potency): 53.7%
Compound 4: the middle estimate sits 23.7 percentage points below what was measured; measured number inside the range.
By their numbers in this assay, from the lowest: compound 3; then compound 2; then compound 4; then compound 1.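

In this assay, 4-methylphenyl to 4-methoxyphenyl gives a number 15.4 percentage points higher from compound 2 to compound 4 (beyond the scatter), so methoxy at this position raises the number, and the rise lies beyond the scatter. The earlier step, a number 28.9 percentage points lower from compound 2 to compound 3 (beyond the scatter), runs the other way, but it involves another ring and another departing group, so a methoxy gives no single direction across these positions. No measurement in hand explains the rise.

From the compounds shown here alone, it remains open what an amine or a longer ether such as ethoxy would give at this position. Also open, going by these compounds, is whether the rise would persist with the 4-fluorophenyl group changed.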